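Carbamoyl Replaces a Sulfur-Bearing Group on a Shared Core

The source may report more compounds than this note shows. Statements on the series, on what has been measured and on what is new or still open speak of the compounds shown alone.

Of the compounds shown here, three on a shared core have been tested in a functional assay on KB cells (Homo sapiens) for cytotoxicity; a higher number here means a weaker inhibitor, a lower number a stronger inhibitor. Compound 1 `NC(=O)c1cn(Cc2ccccc2)c2ncnc(N)c12` gives 75000 nM, compound 2 `CCCn1cc(C(N)=O)c2c(N)ncnc21` gives 100000 nM, and compound 3 `CCOCn1cc(C(=N)S)c2c(N)ncnc21` gives 68000 nM. Going by the values given here, the only single-point step among them, a 1.3-fold higher number from compound 1 to compound 2 (0.12 log units; within the scatter), stays within the scatter. Compound 3 holds the lowest of the three numbers, but its nearest neighbour is compound 1 and its furthest is compound 2, and both of those gaps also lie within the scatter, so no ordering can be read from them.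

Compound 4 `CCOCn1cc(C(N)=O)c2c(N)ncnc21` differs from compound 3 in one place: a group of 3 heavy atoms (1 carbon, 1 nitrogen, 1 oxygen; no ring) in place of a group of 3 heavy atoms (1 carbon, 1 nitrogen, 1 sulfur; no ring), on an aromatic carbon. Among the compounds with values here, no measured step mirrors this exchange, since compounds 1 and 2 already carry the carbamoyl group and differ from each other elsewhere. What the data do show is that carbamoyl-bearing compounds 1 and 2 sit in the same region of this assay as compound 3. He therefore expects the change from compound 3 to compound 4 to produce no step beyond the scatter, a 1.2-fold higher number from compound 3 to compound 4 (0.07 log units; within the scatter). His estimate for compound 4 in this assay is 80000 nM, with a range from 30000 nM to 200000 nM.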

Compound 4, half-maximal inhibitory concentration: > 100000 nM
Compound 4: no number, only a limit (the forecaster's own chance of this, stated with the estimate: 20%); middle value at least 1.2-fold (0.09 log units) from the limit.
By their numbers in this assay, from the lowest: compounds 3, 1 and 2 (each within the scatter of the next).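

Compound 4 is recorded in this assay only as a limit of the assay and not as a number: the limit of > 100000 nM in this assay, at which 1 of the 4 values shown sits.

The exchange on the aromatic carbon from the sulfur-bearing group to carbamoyl, the first one tested directly on the ethoxymethyl-bearing core, gives an at least 1.4-fold higher number from compound 3 to compound 4 (0.16 log units; that floor lies within the scatter), ethoxy in place of phenyl on the saturated chain carbon gives an at least 1.3-fold higher number from compound 1 to compound 4 (0.12 log units; that floor lies within the scatter), and ethoxy in place of ethyl on that carbon gives a number no lower from compound 2 to compound 4 (the limit leaves the size open). The first two of these steps are floors only: they show no step beyond the scatter, but they do not rule one out, and the size of the third cannot be read.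

On these data alone, the true size of the exchange from the sulfur-bearing group to carbamoyl therefore stays open, and so does whether the sulfur-bearing group would give a similar value on the chains of compound 1 or compound 2. How a nitrile, a carboxylic acid or an amine on this same aromatic carbon would stand in this assay is also unknown from the compounds shown.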